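Swapping a fluorinated carbinol for a cyclopropyl sulfoximine

The source may report more compounds than this note shows. Statements on the series, on what has been measured and on what is new or still open speak of the compounds shown alone.

Compound 1 `CC#C[C@H]1CN(S(=O)(=O)c2ccc(N)nc2)CCN1c1ccc(C(O)(COC)C(F)(F)F)cc1`: 202 nM
Compound 2 `CC#CCC(O)(c1ccc(N2CCN(S(=O)(=O)c3ccc(N)nc3)C[C@@H]2C#CC)cc1)C(F)(F)F`: 137 nM

In an assay on cells (Hepatocyte) for inhibition of glucokinase regulatory protein (Mus musculus), with stated times of 20 min and 40 min (a higher number here means that more compound is needed for the effect, a lower number that less compound is needed), compound 2 gives 137 nM, the lower end of the two numbers shown. For the measured compounds named here, its only neighbour is compound 1, which gives 202 nM, and the step of a 1.5-fold lower number from compound 1 to compound 2 (0.17 log units; within the scatter) lies within the scatter, so the two compounds cannot be told apart on these data.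

Compound 3 `CC#C[C@H]1CN(S(=O)(=O)c2ccc(N)nc2)CCN1c1ccc(S(=N)(=O)C2CC2)cc1` differs from compound 2 by a group of 6 heavy atoms (3 carbon, 1 nitrogen, 1 oxygen, 1 sulfur; one three-membered non-aromatic ring of carbon only) in place of a group of 10 heavy atoms (6 carbon, 1 oxygen, 3 fluorine; no ring), on an aromatic carbon. Going by the values given here, the single measured step, a 1.5-fold lower number from compound 1 to compound 2 (0.17 log units; within the scatter), changes a different part of the shared core, so no measured step bears on the change made here, and the expectation rests on the shared core alone. For compound 3 a step of a 1.8-fold higher number from compound 2 to compound 3 (0.26 log units; within the scatter) is therefore expected, with a wide range to reflect the lack of any comparison. Compound 3 is estimated at 250 nM, expected to fall between 50 nM and 1500 nM.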

Compound 3, half-maximal effective concentration: 208 nM
Beside the measured number, compound 3's estimate is 1.2-fold (0.08 log units) above it; measured number inside the range.
By their numbers in this assay, from the lowest: compounds 2, 1 and 3 (each within the scatter of the next).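

For the compounds shown here, until now, no step had touched this position, the aromatic carbon para to a large group. In this assay, the cyclopropyl sulfoximine replaces the propynyl-bearing carbinol with a 1.5-fold higher number from compound 2 to compound 3 (0.18 log units; within the scatter) and the methoxy-bearing carbinol with a 1.0-fold higher number from compound 1 to compound 3 (0.01 log units; within the scatter) as the printed steps, so the three compounds cannot be told apart. Among these compounds, then, the fluorinated carbinol is not required for a number in this range, and a smaller group with a three-membered ring serves equally well in this assay, though nothing measured here explains why.

Still open, going by these compounds, is how much of the sulfoximine matters, for instance whether a methyl group could replace its cyclopropyl ring. It is also unclear how different groups at this carbon, such as a simple amine or a carboxylic acid, would behave.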